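Swapping a five-membered ring for a six-membered one

A few compounds are considered here, and "the series" means these few. Any claim that something is new, unique, unknown or untested is made for them only; others in the source may bear on it.

Of the compounds shown here, three share a core and have been measured in a functional assay on K562 cells (Homo sapiens) for antiproliferative activity, read by CellTiter-Glo and CCK-8 assay, with a stated time of 72 h; a lower number here means a stronger inhibitor of growth, a higher number a weaker inhibitor of growth. Compound 3 `Cc1ccc(NC(=O)c2cccc(C(F)(F)F)c2)cc1N1Cc2cnc(O[C@H]3CCNC3)nc2N(C)C1=O` gives 450 nM and sits at the weak end of this small set. Compound 1 `Cc1ccc(NC(=O)c2cccc(C(F)(F)F)c2)cc1N1Cc2cnc(O[C@H]3CCN(C(=O)OC(C)(C)C)C3)nc2N(C)C1=O` gives 30 nM, and the step of a 15-fold higher number from compound 1 to compound 3 (1.18 log units; beyond the scatter) shows how much is lost when the protecting group on the ring amine is removed. Compound 2 `Cc1ccc(NC(=O)c2cccc(C(F)(F)F)c2)cc1N1Cc2cnc(OC3CCN(C(=O)OC(C)(C)C)CC3)nc2N(C)C1=O`, which carries the same protecting group on a six-membered ring, gives 29 nM, and the values of compound 1 and compound 2 lie within the usual scatter of each other.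

Compound 4 `Cc1ccc(NC(=O)c2cccc(C(F)(F)F)c2)cc1N1Cc2cnc(OC3CCNCC3)nc2N(C)C1=O` differs from compound 3 by the change (piperidin-4-yl in place of pyrrolidin-3-yl on an oxygen on an aromatic ring). Among the compounds with values here, no measured step bears directly on this swap with the amine free; the only comparison, between compound 1 and compound 2, shows no difference between the two rings when the amine is protected. A step of no change at the digits printed from compound 3 to compound 4 (within the scatter) is therefore expected, that is none beyond the scatter. Compound 4 is estimated at 450 nM, in the range 200 nM to 1000 nM.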

Compound 4, concentration for 50% growth inhibition: 220 nM
For compound 4 the middle estimate is 2.0-fold (0.31 log units) above the measured one, and the stated range covers the measured number.
By their numbers in this assay, from the lowest: compounds 2 and 1 (each within the scatter of the next); then compound 4; then compound 3.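

With the ring amine free, the change from pyrrolidin-3-yl to piperidin-4-yl gives a 2.0-fold lower number from compound 3 to compound 4 (0.31 log units; beyond the scatter). With the tert-butoxycarbonyl group in place, compound 1 gives 30 nM and compound 2 gives 29 nM, values that lie within the scatter of each other. Removing the tert-butoxycarbonyl group also weakens growth inhibition on the six-membered ring, with a 7.6-fold higher number from compound 2 to compound 4 (0.88 log units; beyond the scatter), so the loss is not confined to the five-membered ring, and the two losses cannot be told apart: the same change on two cores in this assay, a 15-fold higher number (1.18 log units; beyond the scatter) from compound 1 to compound 3 and a 7.6-fold higher number (0.88 log units; beyond the scatter) from compound 2 to compound 4, 2.0-fold (0.30 log units) apart, within the scatter of two such steps There is also a 7.3-fold higher number from compound 1 to compound 4 (0.87 log units; beyond the scatter), but this step changes the ring and the protecting group together, so it cannot be read as a single change.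

The compounds shown leave open how the mirror-image form of the pyrrolidin-3-yl group would compare. They also leave open what a methyl or acetyl group on the ring nitrogen would give in place of hydrogen or tert-butoxycarbonyl.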